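A Piperazine Swap on a Weak Cell-Growth Inhibitor

The source may hold more compounds than are shown below. What is called first, only, known or untested is meant among the compounds shown, and "the series" means these compounds.

Compound 2 `CC1CCN(c2ccc(Nc3ncc4c(n3)N(C3CCCC3)CC(=O)N4)nc2)CC1` has been tested in a functional assay on HeLa cells (Homo sapiens) for inhibition, read by MTT assay, with a stated time of 48 h; a higher number here means a weaker inhibitor, a lower number a stronger inhibitor. In this assay compound 2 gives only a limit, > 30000 nM. Compound 1 `O=C1CN(C2CCCC2)c2nc(Nc3ccc(N4CCCCC4)cn3)ncc2N1` likewise gives only a limit, > 30000 nM. Going by the values given here, the one measured step, a step that the two limits leave unreadable from compound 1 to compound 2, cannot be sized because of the limit of > 30000 nM in this assay, at which 2 of the 2 values shown sit. Compound 3 `O=C1CN(C2CCCC2)c2nc(Nc3ccc(N4CCNCC4)cn3)ncc2N1` differs from compound 2 by piperazin-1-yl in place of 4-methylpiperidin-1-yl on an aromatic carbon. Among the compounds with values here, no measured step shows this change, and the only step available is unreadable, so the expected result for compound 3 is again a limit, estimated at 30000 nM with a range from 10000 nM to 100000 nM. The expected step of a number no higher from compound 2 to compound 3 (the limit leaves the size open) is none beyond the scatter.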

Compound 3, half-maximal inhibitory concentration: > 30000 nM
Compound 3 ended at the assay's limit; the forecaster's own chance of this, stated with the estimate: 75%; the middle value sits exactly at the limit.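

The steps among compound 1, compound 2 and compound 3 cannot be read, because no value gives a size: the limit of > 30000 nM in this assay, at which 3 of the 3 values shown sit.

The compounds shown leave open how these three groups on the aromatic carbon truly compare in this assay.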